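The source may hold more compounds than are shown below. What is called first, only, known or untested is meant among the compounds shown, and "the series" means these compounds.

- Compound 1 `C=C(CC)C(=O)c1ccc(OCC(=O)Nc2nc3ccccc3s2)c(Cl)c1Cl`: 1500 nM
- Compound 2 `C=C(CC)C(=O)c1ccc(OCC(=O)NC(CS)C(=O)OCC)c(Cl)c1Cl`: 4800 nM

In a functional assay on CLL cells (Homo sapiens) for cytotoxicity, read by MTT assay, with a stated time of 48 h (on this read-out higher numbers stand for an effect only at larger amounts of compound and lower numbers for an effect already at smaller amounts), compound 2 has the higher of the two numbers. Compound 3 `C=C(CC)C(=O)c1ccc(OCC(=O)Nc2ccc(C(=O)O)cc2)c(Cl)c1Cl` keeps the shared core but carries 4-carboxyphenyl in place of 1-(ethoxycarbonyl)-2-sulfanylethyl on an amide-type nitrogen. Going by the values given here, only one measured step bears on this change, since it altered the group at the same place: a 3.2-fold higher number from compound 1 to compound 2 (0.51 log units; beyond the scatter). That step is modest, though beyond the scatter. The entering group is aromatic, as is the 1,3-benzothiazol-2-yl of compound 1, which might suggest a lower number. However, no measured compound carries a 4-carboxyphenyl group, so the direction remains open, and no step beyond the scatter is expected in this assay. The expected step is a 1.1-fold lower number from compound 2 to compound 3 (0.03 log units; within the scatter). For compound 3, the estimated value is 4500 nM, with an expected range of 1500 nM to 14000 nM.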

Compound 3, half-maximal effective concentration: 5000 nM
The estimate for compound 3 lay 1.1-fold (0.05 log units) below the measured number; low and high end bracket the measured number.
By their numbers in this assay, from the lowest: compound 1; then compounds 2 and 3 (each within the scatter of the next).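

In this assay, replacing the open-chain 1-(ethoxycarbonyl)-2-sulfanylethyl on the amide-type nitrogen with the aromatic 4-carboxyphenyl gives a 1.0-fold higher number from compound 2 to compound 3 (0.02 log units; within the scatter), so this swap makes no readable difference. An aromatic ring at this place is therefore not enough to match compound 1, as 4-carboxyphenyl in place of 1,3-benzothiazol-2-yl gives a 3.3-fold higher number from compound 1 to compound 3 (0.52 log units; beyond the scatter), and among these three compounds only compound 1, with its 1,3-benzothiazol-2-yl group, stands apart. Nothing available explains these numbers.

As far as these compounds go, it remains open whether a plain phenyl group, without the carboxylic acid, would give a number closer to that of compound 1 or to those of compound 2 and compound 3. The same question applies to a phenyl group carrying an amine instead.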